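The source may hold more compounds than are shown below. What is called first, only, known or untested is meant among the compounds shown, and "the series" means these compounds.

Measured compounds in this series:

- compound 1, `O=C1C(Nc2ccc(I)cc2)=CC(=O)c2c1nc1n2[C@H]2OC[C@@H](O)[C@H]2OC1`: 3890 nM
- compound 2, `CCc1ccc(NC2=CC(=O)c3nc4n(c3C2=O)[C@H]2OC[C@@H](O)[C@H]2OC4)cc1`: 960 nM
- compound 3, `O=C1C=C(Nc2ccc(C(F)(F)F)cc2)C(=O)c2c1nc1n2[C@H]2OC[C@@H](O)[C@H]2OC1`: > 4000 nM

All three share one core and differ only in the substituent on the aromatic ring of the anilino group. In a functional assay on MCF7 cells (Homo sapiens) for inhibition, read by sulforhodamine B assay (on this read-out lower numbers stand for stronger inhibition and higher numbers for weaker inhibition), compound 1 gives 3890 nM, the higher of the two numbers reported, and the gap to compound 2, which gives 960 nM, lies beyond the scatter. For compound 3 the result is a limit of the assay, not a number, (the limit of > 4000 nM in this assay, at which 1 of the 3 values shown sits). Going by the values given here, the one step that can be sized, an at least 4.1-fold higher number from compound 2 to compound 3 (0.61 log units; beyond the scatter), is a change of substituent on the aromatic ring, not a removal of that ring.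

Compound 4, `CCCN(CCC)C1=CC(=O)c2c(nc3n2[C@H]2OC[C@@H](O)[C@H]2OC3)C1=O`, is not yet measured in this assay. Relative to compound 1 the change is dipropylamino in place of (4-iodophenyl)amino on a double-bonded ring carbon. Among the compounds with values here, none of the measured steps concerns a replacement of the whole anilino group by a dialkylamino group, so the sized step does not bear directly on it; the three anilino compounds merely show that this position is sensitive, with values from a sub-micromolar number up to a limit. For compound 4 the expectation is therefore weak: a number near or past the upper end of the range seen, estimated at 5000 nM, between 1000 nM and 25000 nM. This estimate corresponds to an expected step of a 1.3-fold higher number from compound 1 to compound 4 (0.11 log units; within the scatter).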

Compound 4, half-maximal inhibitory concentration: > 16000 nM
Compound 4 was reported as a limit; the forecaster's own chance of this, stated with the estimate: 50%; middle value at least 3.2-fold (0.50 log units) from the limit.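

Compound 4 is the only compound shown without an aromatic ring on the amino group at this double-bonded ring carbon, and its result in this assay is a limit of the assay, not a number: the limit of > 16000 nM in this assay, at which 1 of the 4 values shown sits. The step, an at least 4.1-fold higher number from compound 1 to compound 4 (0.61 log units; beyond the scatter), lies beyond the scatter and shows that replacing (4-iodophenyl)amino with dipropylamino does not keep even the modest inhibition of compound 1, a size that the limit leaves open on the upper side. Among the compounds shown, numbers short of a limit occur only with an anilino group, in compound 1 and compound 2, although compound 3 goes against a simple link between that group and inhibition, since it keeps the anilino group and also ends at a limit.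

This single change removes the aromatic ring and the hydrogen-bond donor together, and the compounds shown cannot separate the two. A monopropylamino group would keep the donor without the ring, and a piperidine would give a ring without the donor or the aromatic character, so either would help to tell which part of the change matters at this position.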